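Hydroxy to methoxy on the shared core

The source may report more compounds than this note shows. Statements on the series, on what has been measured and on what is new or still open speak of the compounds shown alone.

- compound 1 (`CO[C@@H]1[C@H]2OC(=O)C[C@H]2O[C@@H]1[C@@H](O)c1ccccc1`): 11000 nM
- compound 2 (`CO[C@@H](c1ccccc1)[C@H]1O[C@@H]2CC(=O)O[C@@H]2[C@H]1O`): 8460 nM

In a functional assay on HeLa cells (Homo sapiens) for inhibition, read by MTT assay, with a stated time of 72 h (a higher number here means a weaker inhibitor, a lower number a stronger inhibitor), compound 2 stands within the scatter of compound 1, and the two values show no order. Compound 3 (`CO[C@@H]1[C@H]2OC(=O)C[C@H]2O[C@@H]1[C@@H](OC)c1ccccc1`) differs from compound 2 by methyl in place of hydrogen on an oxygen on a saturated carbon (hydroxy to methoxy), with methyl in place of hydrogen on an oxygen on a saturated carbon. Among the compounds with values here, no measured pair isolates this change. The expectation therefore rests on the close values of compound 1 (11000 nM) and compound 2 (8460 nM). No change beyond the scatter is expected in this assay, and no direction is favoured. The expected 1.1-fold higher number from compound 2 to compound 3 (0.03 log units; within the scatter) is small. For compound 3 the estimated value is 9000 nM (expected range 3000 nM to 25000 nM).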

Compound 3, half-maximal inhibitory concentration: 89300 nM
Beside the measured number, compound 3's estimate is 9.9-fold (1.00 log units) below it; the whole stated range lies below it.
By their numbers in this assay, from the lowest: compounds 2 and 1 (each within the scatter of the next); then compound 3.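

In this assay, hydroxy to methoxy gives an 11-fold higher number from compound 2 to compound 3 (1.02 log units; beyond the scatter) at one oxygen and an 8.1-fold higher number from compound 1 to compound 3 (0.91 log units; beyond the scatter) at the other, so the change is not neutral at either place. Compound 1 and compound 2 each keep one free hydroxy and stand within the scatter of each other, and only compound 3, with no free hydroxy, stands apart. No supporting data bear on the reason for this shift. From the compounds shown here alone, whether the loss of the last hydroxy or the added methyl matters more stays open. An amine or an acetate ester on the same carbon could separate the two.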